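The source may hold more compounds than are shown below. What is called first, only, known or untested is meant among the compounds shown, and "the series" means these compounds.

Measured so far, in a functional assay on LoVo cells (Homo sapiens) for inhibition, read by MTT assay, with a stated time of 72 h; a lower number here means a stronger inhibitor, a higher number a weaker inhibitor:
compound 1 `Cc1noc(C)c1-c1cnc(N)c(Oc2ccc(C(=O)NC3CCCC3)cc2)n1`, compound 1 gives 25200 nM;
compound 2 `Cc1noc(C)c1-c1cnc(N)c(Oc2ccc(C(=O)NC3CCCCC3)cc2)n1`, compound 2 gives 21600 nM.

The two numbers sit within the scatter of each other, so compound 1 stands alongside compound 2 with no separation that can be read as a difference. For the measured compounds named here, the only step measured is a 1.2-fold lower number from compound 1 to compound 2 (0.07 log units; within the scatter), and it bears on the amide-type nitrogen that is the site of the new change.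

Compound 3 `Cc1noc(C)c1-c1cnc(N)c(Oc2ccc(C(=O)Nc3cccc(Cl)n3)cc2)n1` differs from compound 1 as follows: 6-chloropyridin-2-yl in place of cyclopentyl on an amide-type nitrogen. Going by the values given here, the measured step exchanged one saturated ring for another and stayed within the scatter, whereas this one brings in an aromatic ring with a chlorine and one hydrogen-bond acceptor, for which no step has been measured. The account therefore expects a moderate change at most in this assay, with the direction uncertain. The expected step is a 1.7-fold lower number from compound 1 to compound 3 (0.23 log units; within the scatter). Compound 3 is estimated at 15000 nM, in the range 3000 nM to 60000 nM.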

Compound 3, half-maximal inhibitory concentration: 39300 nM
Estimate against measurement, compound 3: 2.6-fold (0.42 log units) below, within the range that was stated.
By their numbers in this assay, from the lowest: compounds 2, 1 and 3 (each within the scatter of the next).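

In this assay, a 1.6-fold higher number from compound 1 to compound 3 (0.19 log units; within the scatter) and a 1.8-fold higher number from compound 2 to compound 3 (0.26 log units; within the scatter) are both read as lying within the scatter, as was the earlier step between the saturated rings. The amide-type nitrogen has therefore now carried an aromatic ring as well as saturated ones, and 6-chloropyridin-2-yl gives no separation that can be read as a difference from either cyclopentyl or cyclohexyl. No measured information is available to explain this result.

The compounds shown leave open whether a plain phenyl, a pyridin-2-yl without the chlorine, or a chain ending in an amine on this nitrogen would separate from these three compounds. They also leave open whether any change to the shared core, away from this amide-type nitrogen, would give a readable difference in this assay.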